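Triazole series: trifluoromethylphenyl position on the ring nitrogen

This account rests on a few compounds, and the source may have more. Where it says the series, first, only, none or still open, it means among the compounds named here.

Measured so far:
compound 1 `Cc1ccc(-n2nc(-c3ccc(C(F)(F)F)cc3O)nc2-c2ccccc2O)cc1`: 94.1%
compound 2 `Oc1cc(C(F)(F)F)ccc1-c1nc(-c2ccccc2O)n(-c2ccccc2C(F)(F)F)n1`: 80%

In a functional assay on PC-12 cells (Rattus norvegicus) for cytotoxicity, read by MTT assay, with stated times of 2 h and 24 h, tested at 5 uM (a lower number here means a weaker effect, a higher number a stronger effect of the compound at the concentration tested), compound 1 gives 94.1% and compound 2 gives 80%. For the measured compounds named here, compound 2 stands lowest of the two numbers; the one step that joins them, a number 14.1 percentage points lower from compound 1 to compound 2 (beyond the scatter), is modest but beyond the scatter.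

Compound 3 `Oc1cc(C(F)(F)F)ccc1-c1nc(-c2ccccc2O)n(-c2cccc(C(F)(F)F)c2)n1` is not yet measured. Its change from compound 2 is 3-(trifluoromethyl)phenyl in place of 2-(trifluoromethyl)phenyl on an aromatic nitrogen. Going by the values given here, no measured step moves a trifluoromethyl group from one position of the phenyl ring to another, so the only related step is a number 14.1 percentage points lower from compound 1 to compound 2 (beyond the scatter), which swaps the whole group on that nitrogen. That step sets the scale of what a change at this position can do here, but it gives no direction for the present one. For compound 3 the expected step is a number 5 percentage points higher from compound 2 to compound 3 (within the scatter), not beyond the scatter. The estimate for compound 3 is 85%, in the range 70% to 98%.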

Compound 3, a percentage reported as activity, at one concentration (the size of the read-out at that concentration, not a potency): 92.2%
Estimate against measurement, compound 3: 7.2 percentage points below; the measured number falls inside the stated range.
By their numbers in this assay, from the lowest: compound 2; then compounds 3 and 1 (each within the scatter of the next).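

In this assay, exchanging 2-(trifluoromethyl)phenyl for 3-(trifluoromethyl)phenyl on the aromatic nitrogen gives a number 12.2 percentage points higher from compound 2 to compound 3 (beyond the scatter), although the two groups have the same atoms, joined differently. Where the group is attached therefore matters at this position, which the earlier step could not show because it exchanged the whole group. With 3-(trifluoromethyl)phenyl in place of 4-methylphenyl, the series shows a number 1.9 percentage points lower from compound 1 to compound 3 (within the scatter), so among these three compounds only the 2-(trifluoromethyl)phenyl group stands apart, and no measurement at hand accounts for this.

As far as these compounds go, it remains open whether a phenyl ring on this nitrogen carrying an amine or a carboxylic acid would keep the read-out of compound 3. With one concentration per compound, these numbers also leave potency open.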